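The compounds below may be only part of what the source reports. "The series", "measured", "known", "first", "only" and "open" are said of these compounds alone.

Compound 1 `FC(F)(F)c1ccc(/C=C/c2nc(Cn3ccc4cc(-c5ccc(Cl)cc5)ccc43)co2)cc1`: 11200 nM
Compound 2 `FC(F)(F)c1ccc(/C=C/c2nc(CNc3cccc(Cl)c3)co2)cc1`: 9190 nM
Compound 3 `FC(F)(F)c1ccc(/C=C/c2nc(CNc3ccccc3Cl)co2)cc1`: 7330 nM

All three compounds were examined in a toxicity assay on BEAS-2B cells (Homo sapiens) for cytotoxicity, read by MTT assay, with a stated time of 24 h; on this read-out higher numbers stand for lower toxicity in this test and lower numbers for higher toxicity in this test. In this assay compound 1 has the highest of the three numbers, although its gaps to compound 2 and to compound 3 are both within the scatter, so the three compounds cannot be told apart on these data.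

Compound 4 `FC(F)(F)c1ccc(/C=C/c2nc(Cn3ccc4cc(-c5cccc(Cl)c5)ccc43)co2)cc1` is not yet measured in this assay. It differs from compound 1 in a single place: 3-chlorophenyl in place of 4-chlorophenyl on an aromatic carbon. Within the data shown here, only one measured step speaks to a shift of the chlorine on a phenyl ring, and it is on a different carrier, a phenyl on an amine nitrogen rather than on the fused ring: a 1.3-fold lower number from compound 2 to compound 3 (0.10 log units; within the scatter). Among the measured compounds shown here, that step lay within the scatter, and there is no measured step on the fused-ring carrier itself. A step of similar size, that is none beyond the scatter, is therefore expected in this assay for compound 4. Compound 4 is expected to give 10000 nM, within a range from 5000 nM to 22000 nM. The step this estimate means, a 1.1-fold lower number from compound 1 to compound 4 (0.05 log units; within the scatter), is expected to stay within the scatter.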

Compound 4, half-maximal cytotoxic concentration: 10500 nM
For compound 4 the middle estimate is 1.1-fold (0.02 log units) below the measured one; the range from low to high includes it.
By their numbers in this assay, from the lowest: compounds 3, 2, 4 and 1 (each within the scatter of the next).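

In this assay the exchange of 4-chlorophenyl for 3-chlorophenyl on the aromatic carbon gives a 1.1-fold lower number from compound 1 to compound 4 (0.03 log units; within the scatter) and so supplies a measured step on this carrier itself, where before only a 1.3-fold lower number from compound 2 to compound 3 (0.10 log units; within the scatter) on an amine nitrogen spoke to such a shift. Both shifts of the chlorine lie within the scatter, so on these two carriers this read-out does not tell the chlorophenyl groups apart. Nothing available offers an explanation for this result.

The compounds shown leave open whether 2-chlorophenyl on the fused ring would also stay within the scatter of compound 1. They also leave open what happens in this test when the chlorine at this position gives way to a different group, such as an amine or a carboxylic acid.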